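Stilbene ether series: replacing the chain-end ring

This account rests on a few compounds, and the source may have more. Where it says the series, first, only, none or still open, it means among the compounds named here.

Compound 2 `C(=C/c1ccccc1OCCCCN1CCCC1)\c1ccccc1` gives the highest number of the three measured in a functional assay on the whole organism with Mus musculus as the target, in the maximal electroshock model, at a dose of 50 mg/kg by the oral route (on this read-out lower numbers stand for less inhibition and higher numbers for more inhibition at the one dose given (going by the name of the read-out)), at 42.9%. Compound 3 `CN(C)CCCCOc1ccc(/C=C/c2ccccc2)cc1` gives 12.5% in this assay, and compound 1 `CN(C)CCCCOc1ccccc1/C=C/c1ccc(Cl)cc1` gives 0%; both gaps to compound 2 lie beyond the scatter of repeated measurements. Compound 4 `CC(=O)N1CCN(CCCCOc2ccccc2/C=C/c2ccccc2)CC1` is not yet measured. It differs from compound 2 by 4-acetylpiperazin-1-yl in place of pyrrolidin-1-yl on a saturated chain carbon, four bonds along the chain from an oxygen on an aromatic ring. For the measured compounds named here, no measured pair shares only this change, so the size of the step is open. Going by the values given here, because compound 2 reaches 42.9% and no tested compound carries the entering group, a drop beyond the scatter is expected. The estimate for compound 4 in this assay is 20%, within a range from 5% to 40%, meaning an expected step of a number 22.9 percentage points lower from compound 2 to compound 4 (beyond the scatter).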

Compound 4, a percentage reported as inhibition, in the whole organism at one dose (the size of the read-out at that dose, not a potency): 0%
Compound 4: middle estimate off by 20 percentage points, on the high side; the measured number lies below the stated range.
By their numbers in this assay, from the lowest: compounds 1 and 4 (each within the scatter of the next); then compound 3; then compound 2.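

For the compounds shown here, the chain end is the first position with a sized single change: in this assay 4-acetylpiperazin-1-yl in place of pyrrolidin-1-yl gives a number 42.9 percentage points lower from compound 2 to compound 4 (beyond the scatter) on the shared core. The read-out at this dose therefore depends strongly on which ring sits at the end of the butyl chain. Nothing measured here accounts for the loss.

Piperidin-1-yl, morpholin-4-yl and piperazin-1-yl without the acetyl group remain open at this position. The compounds shown also do not separate the effect of the acetyl group from that of the six-membered ring.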